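Dimethoxyphenyl Replacing Methoxyphenyl on the Carbonyl Carbon

The source may report more compounds than this note shows. Statements on the series, on what has been measured and on what is new or still open speak of the compounds shown alone.

Compound 1 `CNc1nc(Nc2ccc(C)c(N)c2)ncc1C(=O)Nc1cc(NC(=O)c2ccccc2OC)ccc1C` and compound 2 `CNc1nc(Nc2ccc(C)c(N)c2)ncc1C(=O)Nc1cc(NC(=O)c2ccc(OC)cc2)ccc1C` share one core and differ only in the methoxyphenyl that sits on the carbonyl carbon. In an ADME assay on BaF3 cells (Mus musculus) for antiproliferative activity, read by CellTiter-Glo and CCK-8 assay, with a stated time of 72 h (on this read-out lower numbers stand for stronger inhibition of growth and higher numbers for weaker inhibition of growth), compound 1 reports only a limit, > 10000 nM. In this assay compound 2 likewise reports only a limit, > 10000 nM. Compound 2 therefore stands at the edge of what the assay can read, with no number of its own, and the step that the two limits leave unreadable from compound 1 to compound 2 cannot be sized because both of its values sit at the limit of > 10000 nM in this assay, at which 2 of the 2 values shown sit.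

Compound 3 `CNc1nc(Nc2ccc(C)c(N)c2)ncc1C(=O)Nc1cc(NC(=O)c2cc(OC)cc(OC)c2)ccc1C` carries 3,5-dimethoxyphenyl in place of 4-methoxyphenyl on a carbonyl carbon. Among the compounds with values here, the only measured step that touches this position is the one from compound 1 to compound 2, and it gives no readable size, so no direction beyond the scatter can be drawn from it. With both neighbours at the limit, compound 3 is expected to remain there as well. The step that the limit leaves unreadable from compound 2 to compound 3 is estimated to stay within the scatter. Compound 3 is estimated at 15000 nM in this assay, with a range from 5000 nM to 50000 nM, most likely reported again only as a limit.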

Compound 3, concentration for 50% growth inhibition: > 10000 nM
Compound 3 gave a limit, no number (the forecaster's own chance of this, stated with the estimate: 85%); the middle value does not contradict the limit.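

In this assay compound 3 reports only a limit, > 10000 nM. No step among compound 1, compound 2 and compound 3 can be read or sized: the limit of > 10000 nM in this assay, at which 3 of the 3 values shown sit.

The compounds shown leave open what actual number each of the three has in this assay, and whether any group on this carbonyl carbon gives a readable value.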